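Aryl swap at the saturated ring carbon: compound 4 outlook

The compounds below may be only part of what the source reports. "The series", "measured", "known", "first", "only" and "open" are said of these compounds alone.

Measured compounds:
compound 1 `COc1ccccc1C1C(C#N)=C(N)N(c2cc(OC)c(OC)c(OC)c2)C2=C1C(=O)CC(C)(C)C2` gives 100%
compound 2 `COc1cc(N2C(N)=C(C#N)C(c3ccc([N+](=O)[O-])cc3)C3=C2CC(C)(C)CC3=O)cc(OC)c1OC` gives 80%
compound 3 `COc1cc(N2C(N)=C(C#N)C(c3ccc(C)cc3)C3=C2CC(C)(C)CC3=O)cc(OC)c1OC` gives 90%

All three share one core and differ only in the aryl group on the saturated ring carbon. In a functional assay on Ehrlich cells (Mus musculus) for cytotoxicity, tested at 100 ug/mL (on this read-out higher numbers stand for a stronger effect at the one concentration tested and lower numbers for a weaker effect), compound 3 stands with compound 1 on one side and compound 2 on the other, yet neither gap reaches beyond the scatter, so the three numbers cannot be ranked with confidence. For the measured compounds named here, the only step that stands out is a number 20 percentage points lower from compound 1 to compound 2 (beyond the scatter); the steps of a number 10 percentage points lower from compound 1 to compound 3 (within the scatter) and a number 10 percentage points higher from compound 2 to compound 3 (within the scatter) both lie within it.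

Compound 4 `COc1cc(N2C(N)=C(C#N)C(c3ccccc3O)C3=C2CC(C)(C)CC3=O)cc(OC)c1OC` is not yet measured. Its change from compound 3 is 2-hydroxyphenyl in place of 4-methylphenyl on a saturated ring carbon. The step that bears most on it is a number 10 percentage points lower from compound 1 to compound 3 (within the scatter), where an aryl carrying an oxygen group on the ring gave way to 4-methylphenyl with no shift beyond the scatter; compound 4 carries an oxygen group again, now as 2-hydroxyphenyl. Going by the values given here, no measured compound holds a hydroxy group, so a donor of this kind is untested here. On this basis compound 4 is expected to show a number 5 percentage points higher from compound 3 to compound 4 (within the scatter), that is, no step beyond the scatter. The estimate for compound 4 in this assay is 95%, with a range of 80% to 100%.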

Compound 4, a percentage reported as activity, at one concentration (the size of the read-out at that concentration, not a potency): 10%
Compound 4: the middle estimate sits 85 percentage points above what was measured, and the stated range ends above it.
By their numbers in this assay, from the lowest: compound 4; then compounds 2, 3 and 1 (each within the scatter of the next, the first and the last beyond it).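

Within this assay, the aryl group on the saturated ring carbon can decide nearly the whole read-out: 2-hydroxyphenyl brings a number 80 percentage points lower from compound 3 to compound 4 (beyond the scatter) and a number 70 percentage points lower from compound 2 to compound 4 (beyond the scatter), far larger steps than any seen among the 2-methoxyphenyl, 4-nitrophenyl and 4-methylphenyl compounds. The closest comparison is hydrogen in place of methyl on the aromatic ring's oxygen, with a number 90 percentage points lower from compound 1 to compound 4 (beyond the scatter), so an oxygen on this aryl group does not by itself go with a high number, and this single change separates the two outcomes. Nothing available bears on why the free hydroxy group goes with so low a read-out.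

The compounds shown leave open whether the loss follows the hydroxy group wherever it sits on the aryl ring or only at the place it holds in 2-hydroxyphenyl. They also leave open whether an amine or a carboxylic acid on that ring would give a similarly low number, or whether the drop is particular to the hydroxy group.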